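Swapping the Amine Tail on a Quinoline-Ether Urea

The compounds below may be only part of what the source reports. "The series", "measured", "known", "first", "only" and "open" are said of these compounds alone.

Measured compounds:
compound 1 `COc1cc2c(Oc3c(F)cc(NC(=O)NN4C(=O)C(C)SC4c4c(F)cccc4F)cc3F)ccnc2cc1OCCCN1CCCC1` gives 670 nM
compound 2 `COc1cc2c(Oc3c(F)cc(NC(=O)NN4C(=O)CSC4c4c(F)cccc4F)cc3F)ccnc2cc1OCCCN1CCc2sccc2C1` gives 1410 nM

Of the compounds shown here, two have been measured in a functional assay on HT-29 cells (Homo sapiens) for antiproliferative activity, read by MTT assay, with a stated time of 72 h; a higher number here means a weaker inhibitor, a lower number a stronger inhibitor. Compound 1 `COc1cc2c(Oc3c(F)cc(NC(=O)NN4C(=O)C(C)SC4c4c(F)cccc4F)cc3F)ccnc2cc1OCCCN1CCCC1` gives 670 nM in this assay. Compound 2 `COc1cc2c(Oc3c(F)cc(NC(=O)NN4C(=O)CSC4c4c(F)cccc4F)cc3F)ccnc2cc1OCCCN1CCc2sccc2C1` gives 1410 nM, the higher of the two numbers, and the gap between them is beyond the scatter. The two structures differ in more than one place, so no single change can be tied to that gap.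

Compound 3 `CCN(CC)CCCOc1cc2nccc(Oc3c(F)cc(NC(=O)NN4C(=O)CSC4c4c(F)cccc4F)cc3F)c2cc1OC` has not yet been measured in this assay. It keeps the core of compound 2 and differs only at the chain tail: a group of 5 heavy atoms (4 carbon, 1 nitrogen; no ring) in place of a group of 9 heavy atoms (7 carbon, 1 nitrogen, 1 sulfur; one five-membered aromatic ring with 1 hetero atom, one six-membered non-aromatic ring with 1 hetero atom), on a saturated chain carbon, three bonds along the chain from an oxygen on an aromatic ring. For the measured compounds named here, no measured pair shows this change alone. Going by the values given here, on the two numbers at hand, the only guidance is that compound 1, which also carries a smaller amine at that position but differs elsewhere too, gives 670 nM. The expected step from compound 2 to compound 3 is therefore a 1.6-fold lower number from compound 2 to compound 3 (0.19 log units; within the scatter), a modest lowering that may not exceed the scatter. Compound 3 is expected to give about 900 nM in this assay, within a range of 350 nM to 2500 nM.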

Compound 3, half-maximal inhibitory concentration: 91 nM
The estimate for compound 3 lay 9.9-fold (1.00 log units) above the measured number, outside the stated range (below it).
By their numbers in this assay, from the lowest: compound 3; then compound 1; then compound 2.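

The tail on this saturated chain carbon, three bonds along the chain from an oxygen on an aromatic ring, proves to be a sensitive position: with the rest of the structure held constant, diethylamino in place of the group with one five-membered aromatic ring and one six-membered non-aromatic ring gives a 15-fold lower number from compound 2 to compound 3 (1.19 log units; beyond the scatter) in this assay. The earlier pair could not show this, since compound 1 and compound 2 differ in more than one place, whereas this step ties a large change to the tail alone, and the open-chain diethylamino group is clearly preferred over the fused two-ring amine on this core. Nothing measured here explains why the exchange has so large an effect on the number.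

This single step cannot separate the contribution of the size of the amine from that of its rings or its sulfur atom, so it gives no general trend for the position. From the compounds shown here alone, how a dimethylamino group, a morpholine ring or a longer chain carrying the same diethylamino group would behave on the core of compound 3 remains open.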